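A few compounds are considered here, and "the series" means these few. Any claim that something is new, unique, unknown or untested is made for them only; others in the source may bear on it.

Values in an ADME assay on CCRF-CEM cells (Homo sapiens) for antiproliferative activity, with a stated time of 48 h; on this read-out lower numbers stand for stronger inhibition and higher numbers for weaker inhibition
compound 1 `C=C(Br)C(=O)Nc1ccc(/C=C/C(=O)c2ccc(Cl)cc2)cc1` - 950 nM
compound 2 `C=C(Br)C(=O)Nc1ccc(/C=C/C(=O)c2ccc(OC)cc2)cc1` - 1400 nM
compound 3 `C=C(Br)C(=O)Nc1ccc(/C=C/C(=O)c2cc(OC)c(OC)c(OC)c2)cc1` - 1100 nM

Compound 1 does not stand apart from the others. With compound 1 at 950 nM in this assay the number lies within the usual scatter of both neighbours, so it cannot be ranked against them.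

The open question concerns compound 4 `C=C(Br)C(=O)Nc1ccc(/C=C/C(=O)c2ccc(OCC)cc2)cc1` which is compound 1 with ethoxy in place of chloro on an aromatic carbon, para to a large group. Within the data shown here, the change is ethoxy in place of chloro on an aromatic carbon and no measured compound carries ethoxy, so the data hold no direct answer.

The closest guide is the swap of chloro for methoxy at the same place, which gave a 1.5-fold higher number from compound 1 to compound 2 (0.17 log units; within the scatter) and so a step that cannot be told from noise. Compound 3, with further methoxy groups on that ring, gives 1100 nM and this also sits within the scatter of compound 1.

On this evidence no step beyond the scatter is expected in this assay and the estimated step is a 1.4-fold higher number from compound 1 to compound 4 (0.14 log units; within the scatter) with a slight lean towards the methoxy result. For compound 4 the estimated value is 1300 nM with an expected range from 700 nM to 2400 nM in repeat measurements.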

Compound 4, half-maximal inhibitory concentration: 750 nM
Estimate against measurement, compound 4: 1.7-fold (0.24 log units) above, within the range that was stated.
By their numbers in this assay, from the lowest: compounds 4, 1, 3 and 2 (each within the scatter of the next).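

In this assay, ethoxy in place of chloro gives a 1.3-fold lower number from compound 1 to compound 4 (0.10 log units; within the scatter), and methyl in place of a hydrogen on the chain carbon bound to the oxygen, which turns methoxy into ethoxy, gives a 1.9-fold lower number from compound 2 to compound 4 (0.27 log units; within the scatter). This position, para to a large group, has now carried chloro, methoxy and ethoxy, and none of the three steps among them can be told from noise, even though ethoxy brings 3 heavy atoms where chloro has 1 and adds a hydrogen-bond acceptor. Nothing measured alongside these numbers offers an explanation for where they fall.

Still open, on these data alone, is whether a different kind of group at this place, such as an amine, a carboxylic acid or a longer chain like butoxy, would produce a step beyond the scatter. Also open is how much the number would respond to a change in the shared core, which stays the same in every compound shown here.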